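The source may hold more compounds than are shown below. What is called first, only, known or untested is meant among the compounds shown, and "the series" means these compounds.

Compound 1 (`CCCCCCCCCCCCCCNC(=O)[C@H](CO)NCc1ccccc1O`) 75300 nM
Compound 2 (`CCCCCCCCCCCCCCNC(=O)[C@H](CO)NCc1ccccc1OC`) 100000 nM
Compound 3 (`CCCCCCCCCCCCCCNC(=O)[C@H](CO)NCc1ccccc1[N+](=O)[O-]`) not yet measured

In a functional assay on cells (Homo sapiens) for cytotoxicity, read by MTT assay, with a stated time of 24 h (on this read-out higher numbers stand for weaker inhibition and lower numbers for stronger inhibition), compound 1 gives 75300 nM and compound 2 gives 100000 nM. For the measured compounds named here, the only measured step is a 1.3-fold higher number from compound 1 to compound 2 (0.12 log units; within the scatter), so compound 2 cannot be told apart from compound 1 on these numbers.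

The next change leads to compound 3, with nitro in place of methoxy on an aromatic carbon, ortho to a large group (nitro in place of methoxy on an aromatic carbon). Going by the values given here, the one measured step bears on this only indirectly. Among the compounds with values here, it is methyl in place of hydrogen on an oxygen on an aromatic ring, and no measured compound carries a nitro. With only a 1.3-fold higher number from compound 1 to compound 2 (0.12 log units; within the scatter) as a guide, no step beyond the scatter is expected in this assay, in either direction, and this expectation rests on thin evidence. The estimate amounts to an expected 1.3-fold lower number from compound 2 to compound 3 (0.10 log units; within the scatter). For compound 3 the expected value is 80000 nM, with an estimated range from 35000 nM to 160000 nM.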

Compound 3, half-maximal inhibitory concentration: 29400 nM
Compound 3: middle estimate off by 2.7-fold (0.43 log units), on the high side; measured number outside the range, below it.
By their numbers in this assay, from the lowest: compound 3; then compounds 1 and 2 (each within the scatter of the next).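

In this assay, the aromatic carbon ortho to a large group proved able to change the read-out, which the earlier pair had not shown: the swap from hydroxy to methoxy at this carbon stayed within the scatter, whereas nitro in place of methoxy gave a 3.4-fold lower number from compound 2 to compound 3 (0.53 log units; beyond the scatter) and nitro in place of hydroxy gave a 2.6-fold lower number from compound 1 to compound 3 (0.41 log units; beyond the scatter). Both steps lie beyond the scatter and point towards stronger inhibition, so compound 3 stands apart from compound 1 and compound 2, although both steps are modest and the two compounds it is compared with cannot be told apart from each other. Nothing available explains why nitro differs from the other two groups here, so the result stands as an observation only.

As far as these compounds go, with a single nitro compound, it remains open whether the shift belongs to nitro alone or would also appear with a group such as an amine, a nitrile or a carboxylic acid on the same carbon. Also open, from the compounds shown here alone, is whether the step would persist with nitro on another carbon of the ring, or with a shorter or longer chain on the amide.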